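The source may report more compounds than this note shows. Statements on the series, on what has been measured and on what is new or still open speak of the compounds shown alone.

Compound 1 `CC(C)C[S+]([O-])CCCCN=C=S`: 4980 nM
Compound 2 `[O-][S+](CCCCN=C=S)Cc1cccs1`: 6220 nM

Both numbers come from an ADME assay on Vero cells (Chlorocebus sabaeus) for cytotoxicity, read by MTT assay, with a stated time of 72 h; a lower number here means a stronger inhibitor, a higher number a weaker inhibitor. In this assay, among the compounds with values here, compound 2 gives 6220 nM, which puts it level with compound 1, the only other measured compound, within the scatter of repeated measurements.

The next structure is compound 3 `[O-][S+](CCCCN=C=S)Cc1ccco1`, which has not yet been measured. It differs from compound 2 at one place: furan-2-yl in place of thiophen-2-yl on a saturated chain carbon bound to a sulfur. Put simply, this is furan-2-yl in place of thiophen-2-yl on a saturated chain carbon bound to a sulfur.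

Within the data shown here, only one measured step bears on this place: a 1.2-fold higher number from compound 1 to compound 2 (0.10 log units; within the scatter). That step put thiophen-2-yl in place of isopropyl, and its two values remain within the scatter of each other. Among the measured compounds shown here, this is thin evidence, as it is a single step and no furan-2-yl compound has been measured. Even so, no step beyond the scatter is expected in this assay, in either direction.

The expected step is a 1.1-fold lower number from compound 2 to compound 3 (0.03 log units; within the scatter). For compound 3 the estimated value is 5800 nM, with an expected range from 2900 nM to 11500 nM.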

Compound 3, half-maximal inhibitory concentration: 5250 nM
Compound 3: middle estimate off by 1.1-fold (0.04 log units), on the high side; low and high end bracket the measured number.
By their numbers in this assay, from the lowest: compounds 1, 3 and 2 (each within the scatter of the next).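

Putting furan-2-yl in place of thiophen-2-yl on a saturated chain carbon bound to a sulfur gives a 1.2-fold lower number from compound 2 to compound 3 (0.07 log units; within the scatter) in this assay. Exchanging the sulfur of the five-membered aromatic ring for oxygen therefore leaves the reading level with that of the thiophen-2-yl compound, which is a more direct comparison than the earlier step, where the two groups had less in common. Furan-2-yl in place of isopropyl gives a 1.1-fold higher number from compound 1 to compound 3 (0.02 log units; within the scatter), so all three groups now sit level at this place in this set, and the data offer no explanation for that.

Going by these compounds, all three compounds carry a group without a hydrogen-bond donor or a net charge as far as the printed counts go for the two rings, so it remains open whether a quite different group at this place, such as an amine or a carboxylic acid, would produce a step beyond the scatter. On these data alone, it also remains open whether a longer chain at this place would leave the number where it is.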